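The source may hold more compounds than are shown below. What is called first, only, known or untested is meant among the compounds shown, and "the series" means these compounds.

In a physicochemical assay for solubility, at pH 7.4 (on this read-out higher numbers stand for higher solubility and lower numbers for lower solubility), compound 1 `Cc1cc(NC(=O)Nc2ccc(Cl)c(Cl)c2)c2ccccc2n1` gives 300 nM and compound 2 `CSc1ccc(NC(=O)Nc2cc(C)nc3ccccc23)cc1` gives 1300 nM, the higher of the two numbers and a gap beyond the usual scatter. Compound 3 `COC(=O)c1ccc(NC(=O)Nc2cc(C)nc3ccccc23)cc1` has not yet been measured. It carries methoxycarbonyl in place of methylsulfanyl on an aromatic carbon, para to a large group. Among the compounds with values here, no measured pair shows this exchange, so the expectation stays close to compound 2 at 1300 nM. The expected change, a 1.3-fold lower number from compound 2 to compound 3 (0.11 log units; within the scatter), is slightly downward and within the scatter. The estimate for compound 3 is 1000 nM, with an expected range of 300 nM to 3500 nM.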

Compound 3, solubility: 1200 nM
Estimate against measurement, compound 3: 1.2-fold (0.08 log units) below, and the stated range covers the measured number.
By their numbers in this assay, from the lowest: compound 1; then compounds 3 and 2 (each within the scatter of the next).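

In this assay, within the data shown here, methoxycarbonyl in place of methylsulfanyl on this aromatic carbon, para to a large group, gives a 1.1-fold lower number from compound 2 to compound 3 (0.03 log units; within the scatter) in the only pair that shows this exchange. The position therefore takes a group of 4 heavy atoms instead of 2, with 2 hydrogen-bond acceptors instead of 1, without a change beyond the scatter. Nothing available explains this result. One pair cannot show whether other groups behave the same way here. On these data alone, how a carboxylic acid or an amine on this carbon would read remains open.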